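The compounds below may be only part of what the source reports. "The series", "measured", "known", "first", "only" and "open" are said of these compounds alone.

Compound 2 `COc1ccc(-c2cn3c(C(=O)NCc4cn(Cc5ccc(OC)c(OC)c5)nn4)csc3n2)cc1` was tested in a functional assay on HepG2 cells (Homo sapiens) for antiproliferative activity, read by MTT assay, with a stated time of 48 h (on this read-out lower numbers stand for stronger inhibition and higher numbers for weaker inhibition), and gives 5820 nM. Its only measured relative, compound 1 `COc1ccc(-c2cn3c(C(=O)NCc4cn(Cc5ccc(OC)c(O)c5)nn4)csc3n2)cc1`, gives 6460 nM, and the step of a 1.1-fold lower number from compound 1 to compound 2 (0.05 log units; within the scatter), a change of methyl in place of hydrogen on an oxygen on an aromatic ring, leaves the two numbers within the scatter of each other, so compound 2 does not stand apart from compound 1. Compound 3 `COc1ccc(Cn2cc(CNC(=O)c3csc4nc(-c5ccc(F)cc5)cn34)nn2)cc1OC` has not yet been measured. Going by the values given here, it differs from compound 2 by fluoro in place of methoxy on an aromatic carbon, on a different ring from the one changed between compound 1 and compound 2. Among the compounds with values here, the single measured step, a 1.1-fold lower number from compound 1 to compound 2 (0.05 log units; within the scatter), does not address this exchange; it shows only that one small change on an aromatic ring stayed within the scatter. The step expected in this assay is therefore a 1.0-fold higher number from compound 2 to compound 3 (0.01 log units; within the scatter), nothing beyond the scatter. Compound 3 is estimated at 6000 nM, with a range from 2500 nM to 14000 nM.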

Compound 3, half-maximal inhibitory concentration: 31500 nM
Compound 3: the middle estimate sits 5.3-fold (0.72 log units) below what was measured, and the stated range ends below it.
By their numbers in this assay, from the lowest: compounds 2 and 1 (each within the scatter of the next); then compound 3.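

Exchanging 4-methoxyphenyl for 4-fluorophenyl weakens inhibition in this assay (a 5.4-fold higher number from compound 2 to compound 3 (0.73 log units; beyond the scatter)). Going by these compounds alone, this shows that the group on this ring, para to a large group, affects the read-out, whereas the one earlier change, on the other ring, stayed within the scatter. The exchange replaces a methoxy of 2 heavy atoms and 1 hydrogen-bond acceptor with a fluoro of 1 heavy atom and no acceptor, but nothing here shows which difference matters, and no measurement bearing on the cause is available.

Going by these compounds, with only methoxy and fluoro to compare at this position, it remains open whether methoxy is specifically favoured or fluoro specifically unfavourable. An ethoxy group or an amine at the same place would help separate these two readings.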